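This account rests on a few compounds, and the source may have more. Where it says the series, first, only, none or still open, it means among the compounds named here.

Two compounds of this series have a number in an assay for inhibition of RAC-alpha serine/threonine-protein kinase (Homo sapiens), read by HTRF, with a stated time of 1 h; a higher number here means a weaker inhibitor, a lower number a stronger inhibitor. Compound 1 `Cn1ncc(Cl)c1-c1cc(C(=O)N[C@@H]2CNCC[C@H]2c2ccc(C(F)(F)F)cc2)oc1Cl` gives 9.3 nM, and compound 2 `Cn1ncc(Cl)c1-c1cc(C(=O)N[C@@H]2CN[C@H](CC(=O)O)C[C@H]2c2ccc(Cl)c(Cl)c2)oc1Cl` gives 1.94 nM; compound 2 thus stands lowest of the two, with compound 1 the nearest and clearly higher, beyond the scatter. Compound 3 `CCC[C@@H]1C[C@@H](c2ccc(Cl)c(Cl)c2)[C@H](NC(=O)c2cc(-c3c(Cl)cnn3C)c(Cl)o2)CN1` is not yet measured. It differs from compound 2 by ethyl in place of carboxy on a saturated chain carbon bound to a saturated ring carbon. Going by the values given here, no measured pair shows this kind of change, so a step of small size in either direction is expected, likely none beyond the scatter, as a 1.8-fold higher number from compound 2 to compound 3 (0.26 log units; within the scatter). For compound 3 the estimate in this assay is 3.5 nM, within 1.2 nM to 11 nM.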

Compound 3, half-maximal inhibitory concentration: 10.4 nM
For compound 3 the middle estimate is 3.0-fold (0.47 log units) below the measured one, within the range that was stated.
By their numbers in this assay, from the lowest: compound 2; then compounds 1 and 3 (each within the scatter of the next).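

In this assay, going by these compounds alone, the saturated chain carbon bound to a saturated ring carbon proves sensitive to its substituent: ethyl in place of carboxy, or equally propyl in place of carboxymethyl, gives a 5.4-fold higher number from compound 2 to compound 3 (0.73 log units; beyond the scatter), the first single-place step. Of this pair, the carboxymethyl compound 2 holds the lower number. Nothing measured here bears on the reason for this step.

Still open, from the compounds shown here alone, is where an amine, a primary amide or a methyl ester at this place would fall relative to compound 2 and compound 3. A longer chain in place of propyl also remains untested by the compounds shown.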